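A few compounds are considered here, and "the series" means these few. Any claim that something is new, unique, unknown or untested is made for them only; others in the source may bear on it.

In a functional assay on HepG2 cells (Homo sapiens) for cytotoxicity, read by MTT assay, with a stated time of 24 h (on this read-out higher numbers stand for weaker inhibition and lower numbers for stronger inhibition), three compounds built on a shared core have been measured so far. Compound 1 `COc1cc(/C=C2\CN(C)C/C(=C\c3ccccc3F)C2=O)cc(OC)c1OC` gives 670 nM, compound 2 `COc1cc(/C=C2\CN(C)C/C(=C\c3ccc(C#N)cc3)C2=O)cc(OC)c1OC` gives 1140 nM, and compound 3 `CN1C/C(=C\c2ccc(F)cc2)C(=O)/C(=C/c2cccc([N+](=O)[O-])c2)C1` gives 9340 nM. That last value is the highest of the three numbers and lies beyond the scatter from both of the others.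

Compound 4 `CN1C/C(=C\c2cccc(Br)c2)C(=O)/C(=C/c2cccc([N+](=O)[O-])c2)C1` departs from compound 3 in one place: 3-bromophenyl in place of 4-fluorophenyl on a double-bonded chain carbon bound to a double-bonded ring carbon. Here 3-bromophenyl stands in place of 4-fluorophenyl on a double-bonded chain carbon bound to a double-bonded ring carbon.

For the measured compounds named here, only one measured step offers any guidance. It is a 1.7-fold higher number from compound 1 to compound 2 (0.23 log units; within the scatter), where 4-cyanophenyl replaces 2-fluorophenyl at the same kind of place, and that step stays within the scatter. Going by the values given here, it is a weak guide, since compound 1 and compound 2 also differ from compound 3 elsewhere in their structures, and no measured compound carries a bromine. On this single small step, no change beyond the scatter is expected in this assay. The estimated step is a 1.3-fold lower number from compound 3 to compound 4 (0.13 log units; within the scatter). For compound 4 the estimated value is 7000 nM, with an expected range from 2500 nM to 16000 nM.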

Compound 4, half-maximal inhibitory concentration: 4890 nM
For compound 4 the middle estimate is 1.4-fold (0.16 log units) above the measured one; the measured number falls inside the stated range.
By their numbers in this assay, from the lowest: compounds 1 and 2 (each within the scatter of the next); then compounds 4 and 3 (each within the scatter of the next).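

The step in this assay is a 1.9-fold lower number from compound 3 to compound 4 (0.28 log units; within the scatter), so exchanging 4-fluorophenyl for 3-bromophenyl, which changes both the halogen and its place on the ring while leaving the rest of the molecule untouched, produces no change that can be told apart from the scatter. This is the second step on a double-bonded chain carbon bound to a double-bonded ring carbon, after a 1.7-fold higher number from compound 1 to compound 2 (0.23 log units; within the scatter). The two steps have different groups elsewhere in the molecule, and they show that a swap at this kind of place can stay within the scatter in more than one setting, at least for these four substituted phenyl groups. No measurement is available that explains this outcome or says how these groups act in the cells.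

The single swap changes the halogen and its ring place together, so the compounds shown cannot separate the two changes. Also open, going by these compounds, is whether this place would respond more strongly to a phenyl ring carrying an amine or a carboxylic acid, or to a longer chain instead of the ring, since every group compared here is a phenyl ring with a single small substituent.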